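The compounds below may be only part of what the source reports. "The series", "measured", "known", "first", "only" and "open" are said of these compounds alone.

Compound 1 `CC(C)(C)c1ccc(N2CCN(Cc3ccc([N+](=O)[O-])o3)CC2)cc1` and compound 2 `COc1cccc(N2CCN(Cc3ccc([N+](=O)[O-])o3)CC2)c1` share one core and differ only in the group carried on the six-membered aromatic ring. In an ADME assay on HepG2 cells (Homo sapiens) for cytotoxicity, read by MTT assay, with a stated time of 24 h (a higher number here means that more compound is tolerated, a lower number that less compound is tolerated), compound 1 gives > 63000 nM, which is a limit of the assay and not a number. In this assay compound 2 gives > 63000 nM, again a limit rather than a number. Compound 2 therefore stands at the limit of > 63000 nM in this assay, at which 2 of the 2 values shown sit, and nothing on the numbers shown separates it from compound 1. Compound 3 `N#Cc1cccc(N2CCN(Cc3ccc([N+](=O)[O-])o3)CC2)c1` is the next member, made by one change: cyano in place of methoxy on an aromatic carbon. Among the measured compounds shown here, no measured step for this change exists, so any expectation rests on the two limits alone. For compound 3 the expected step is a number no higher from compound 2 to compound 3 (the limit leaves the size open), a change of no more than the usual scatter, with the read-out most likely again reported only as a limit. The estimate for compound 3 in this assay is 63000 nM, with a range from 30000 nM to 150000 nM.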

Compound 3, half-maximal cytotoxic concentration: > 64000 nM
Compound 3 gave a limit, no number (the forecaster's own chance of this, stated with the estimate: 80%); middle value at least 1.0-fold (0.00 log units) from the limit.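

In this assay compound 3 gives > 64000 nM, a limit and not a number. Among the compounds shown here, compound 2 gives > 63000 nM, also a limit, so no step from compound 2 to compound 3 can be read. The compounds shown leave open whether cyano and methoxy differ at all in this read-out.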